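The source may hold more compounds than are shown below. What is called first, only, known or untested is meant among the compounds shown, and "the series" means these compounds.

Among the compounds with values here, compound 2 `Clc1ccc(OCc2nc3ccccc3n2CCCC2CCCCN2)cc1` stands with the highest number of the two measured so far in an assay on isolated protein for binding affinity to Neuropeptide Y receptor type 1 (Homo sapiens) (a lower number here means a stronger inhibitor, a higher number a weaker inhibitor), where compound 2 gives 3230 nM. Within the data shown here, its only neighbour is compound 1 `Clc1ccc(OCc2nc3ccccc3n2CCCC2CCNCC2)cc1`, which in this assay gives 980 nM; the step of a 3.3-fold higher number from compound 1 to compound 2 (0.52 log units; beyond the scatter) is the one measured change. Compound 3 `Clc1ccc(OCc2nc3ccccc3n2CCN2CCCCC2)cc1` has not yet been measured. It differs from compound 2 by piperidin-1-yl in place of (piperidin-2-yl)methyl on a saturated chain carbon, two bonds along the chain from an aromatic nitrogen. Among the measured compounds shown here, no measured step covers this exact change; the step from compound 1 to compound 2 only shows that changing how the saturated ring is attached shifts the number by a modest amount. On that basis the step of a 2.2-fold lower number from compound 2 to compound 3 (0.33 log units; beyond the scatter) is expected to be modest, with the direction uncertain but a lower number held slightly more likely given that compound 1 with 980 nM sits below compound 2. For compound 3 the estimate in this assay is 1500 nM, within a range from 400 nM to 6000 nM.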

Compound 3, inhibition constant: > 100000 nM
Compound 3: no number, only a limit; the forecaster's own chance of this, stated with the estimate: 5%; at least 66-fold (1.82 log units) between middle value and limit.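

In this assay, compound 3 gives a limit of the assay and not a number: the limit of > 100000 nM in this assay, at which 1 of the 3 values shown sits. The result is read through two steps, an at least 30-fold higher number from compound 2 to compound 3 (1.49 log units; beyond the scatter) and an at least 100-fold higher number from compound 1 to compound 3 (2.00 log units; beyond the scatter), and both are large, whereas the earlier change of attachment on a ring carbon was only modest. So this position tolerates a move from piperidin-4-yl to piperidin-2-yl far better than the change to piperidin-1-yl, which has 0 hydrogen-bond donors where (piperidin-2-yl)methyl has 1.

The change to piperidin-1-yl alters the ring's attachment and the chain together, so these compounds cannot tell which of the two accounts for the step. A 3-(piperidin-1-yl)propyl group on the shared core would keep the longer chain and separate them.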